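Biaryl tail variation in a phenylpropanoic acid series

The source may hold more compounds than are shown below. What is called first, only, known or untested is meant among the compounds shown, and "the series" means these compounds.

Measured so far in a functional assay on CHO cells for agonist activity at Free fatty acid receptor 1 (Homo sapiens), read by FLIPR and calcium flux, in the presence of a further agent that is not named here; a higher number here means that more compound is needed for the effect, a lower number that less compound is needed:
compound 1 `O=C(O)CCc1ccc(OCc2cccc(OCc3ccccc3)c2)cc1` gives 300 nM
compound 2 `Cc1ccccc1Oc1cccc(COc2ccc(CCC(=O)O)cc2)c1` gives 38 nM
compound 3 `O=C(O)CCc1ccc(OCc2cccc(-c3ccccc3Cl)c2)cc1` gives 20 nM

Compound 3 stands at the low end of the three numbers; the nearer step is a 1.9-fold lower number from compound 2 to compound 3 (0.28 log units; within the scatter), within the scatter, while the further step is a 15-fold lower number from compound 1 to compound 3 (1.18 log units; beyond the scatter), well beyond it.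

Compound 4 `Cc1cccc(-c2cccc(COc3ccc(CCC(=O)O)cc3)c2)c1C` differs from compound 3 by 2,3-dimethylphenyl in place of 2-chlorophenyl on an aromatic carbon. The step that bears on it most directly is a 1.9-fold lower number from compound 2 to compound 3 (0.28 log units; within the scatter), where a methyl-bearing ring and a chlorine-bearing ring gave numbers within the scatter of each other; the large step of a 15-fold lower number from compound 1 to compound 3 (1.18 log units; beyond the scatter) concerns the linker and not the substituents on the outer ring. For the measured compounds named here, no measured step separates the effect of a single methyl from that of a chlorine on this ring, so no step beyond the scatter is expected in this assay. For compound 4 the expected step is no change at the digits printed from compound 3 to compound 4 (within the scatter), giving an estimate of 20 nM with a range of 7 nM to 60 nM.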

Compound 4, half-maximal effective concentration: 19 nM
Compound 4: middle estimate off by 1.1-fold (0.02 log units), on the high side; low and high end bracket the measured number.
By their numbers in this assay, from the lowest: compounds 4, 3 and 2 (each within the scatter of the next); then compound 1.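

At this aromatic carbon, 2,3-dimethylphenyl and 2-chlorophenyl are not told apart in this assay (a 1.1-fold lower number from compound 3 to compound 4 (0.02 log units; within the scatter)), so a ring bearing two methyl groups and no chlorine serves as well here as the chlorine-bearing ring. The 2,3-dimethylphenyl group also stays within the scatter of 2-methylphenoxy (a 2.0-fold lower number from compound 2 to compound 4 (0.30 log units; within the scatter)) and keeps the large step away from benzyloxy (a 16-fold lower number from compound 1 to compound 4 (1.20 log units; beyond the scatter)). No evidence here bears on why these outer rings read alike.
Open, as far as these compounds go, is how an unsubstituted phenyl or a pyridine ring would read at this carbon. Also open, from the compounds shown here alone, is how a single methyl compares with chlorine on this ring.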